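Amide variation on a shared core: cytotoxicity notes

This account rests on a few compounds, and the source may have more. Where it says the series, first, only, none or still open, it means among the compounds named here.

Measured so far:
compound 1 `COc1ccc(C(=O)NC[C@H]2c3[nH]c4ccccc4c3C[C@H]3[C@H]4c5[nH]c6ccccc6c5C[C@@H]([C@H](C#N)N23)N4C)cc1`: 600 nM
compound 2 `CN1[C@@H]2c3[nH]c4ccccc4c3C[C@H]1[C@H](C#N)N1[C@@H](CNC(=O)c3ccc4ccccc4n3)c3[nH]c4ccccc4c3C[C@@H]21`: 150 nM
compound 3 `CN1[C@@H]2c3[nH]c4ccccc4c3C[C@H]1[C@H](C#N)N1[C@@H](CNC(=O)c3cc4ccccc4s3)c3[nH]c4ccccc4c3C[C@@H]21`: 3180 nM

All three were run in a functional assay on MCF7 cells (Homo sapiens) for cytotoxicity, read by MTT assay, with a stated time of 72 h; on this read-out higher numbers stand for weaker inhibition and lower numbers for stronger inhibition. Compound 1 holds the middle of the three numbers: a 4.0-fold lower number from compound 1 to compound 2 (0.60 log units; beyond the scatter) and a 5.3-fold higher number from compound 1 to compound 3 (0.72 log units; beyond the scatter), so the amide aryl group moves the read-out in both directions, with a 21-fold higher number from compound 2 to compound 3 (1.33 log units; beyond the scatter) spanning the set.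

Compound 4 `CN1[C@@H]2c3[nH]c4ccccc4c3C[C@H]1[C@H](C#N)N1[C@@H](CNC(=O)/C=C/c3cccc(C(F)(F)F)c3)c3[nH]c4ccccc4c3C[C@@H]21` changes the same place, (2-(3-(trifluoromethyl)phenyl)ethenyl in place of 4-methoxyphenyl on a carbonyl carbon). Both measured steps alter the group on this carbonyl carbon, but neither brings in a double bond outside aromatic rings or a trifluoromethyl group, so they set only the likely scale, not the direction. A modest shift is expected, a 1.2-fold higher number from compound 1 to compound 4 (0.07 log units; within the scatter), with the range kept wide. For compound 4 the expected value is 700 nM, between 200 nM and 2500 nM.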

Compound 4, half-maximal inhibitory concentration: 110 nM
Beside the measured number, compound 4's estimate is 6.4-fold (0.80 log units) above it; measured number outside the range, below it.
By their numbers in this assay, from the lowest: compounds 4 and 2 (each within the scatter of the next); then compound 1; then compound 3.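

The group on this carbonyl carbon need not be directly aryl: 2-(3-(trifluoromethyl)phenyl)ethenyl, with its double bond outside aromatic rings, gives a 5.5-fold lower number from compound 1 to compound 4 (0.74 log units; beyond the scatter) and a 29-fold lower number from compound 3 to compound 4 (1.46 log units; beyond the scatter) in this small set. Set against the quinolin-2-yl amide, it gives a 1.4-fold lower number from compound 2 to compound 4 (0.13 log units; within the scatter) and so stands level with it, which shows that a low number here does not depend on quinolin-2-yl. No measured evidence accounts for these shifts.

The double bond and the trifluoromethyl group enter together, and their separate contributions remain unresolved. Going by these compounds, whether an amine or a carboxylic acid in place of trifluoromethyl would hold the number also stays open.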